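The source may report more compounds than this note shows. Statements on the series, on what has been measured and on what is new or still open speak of the compounds shown alone.

Measured so far in a functional assay on B16 cells (Mus musculus) for cytotoxicity, read by MTT assay, with a stated time of 3 days; a higher number here means a weaker inhibitor, a lower number a stronger inhibitor:

Compound 1 `COc1ccc(C(=O)/C=C/c2ccccc2)cc1N` sits at a limit of the assay rather than at a number, namely > 100000 nM.
Compound 2 `COc1ccc(/C=C/C(=O)c2ccc(OC)c(N)c2)cc1` gives 43000 nM.
Compound 3 `COc1ccc(/C=C/C(=O)c2ccc(OC)c([N+](=O)[O-])c2)cc1OC` also sits at a limit of the assay, namely > 100000 nM.

Compound 1 and compound 2 share a core and differ in one place: methoxy in place of hydrogen on an aromatic carbon. In this assay this gives an at least 2.3-fold lower number from compound 1 to compound 2 (0.36 log units; beyond the scatter); the size is known only as a bound because of the limit of > 100000 nM in this assay, at which 2 of the 3 values shown sit. Compound 4 `COc1ccc(C(=O)/C=C/c2cc(OC)c(OC)c(OC)c2)cc1[N+](=O)[O-]`, not yet measured, is related to compound 3 by the same kind of change: methoxy in place of hydrogen on an aromatic carbon. The surroundings are not identical, though: in compound 2 the methoxy enters para to a large group, whereas in compound 4 it enters ortho to a methoxy group, meta to a large group and meta to a methoxy group. How the core of compound 3 differs from the core of compound 1 is not broken down here. Going by the values given here, two cautions remain: the starting point of the new step, compound 3, is itself only a limit, and the one measured example of this kind of change is also only a bound. A step of roughly the same kind is nonetheless expected from compound 3 to compound 4, an at least 1.6-fold lower number from compound 3 to compound 4 (0.22 log units; that floor lies within the scatter), resting on an at least 2.3-fold lower number from compound 1 to compound 2 (0.36 log units; beyond the scatter). Compound 4 is therefore estimated at about 60000 nM in this assay, most likely between 15000 nM and 300000 nM, with a real chance that only a limit is reported again.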

Compound 4, half-maximal inhibitory concentration: > 100000 nM
Compound 4: no number, only a limit; the forecaster's own chance of this, stated with the estimate: 45%; at least 1.6-fold (0.22 log units) between middle value and limit.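

In this assay, compound 3 and compound 4 both sit at a limit rather than at a number, so no size can be read for the step between them, because neither end of it is a measured value: the limit of > 100000 nM in this assay, at which 3 of the 4 values shown sit. The compounds shown leave open whether methoxy in place of hydrogen on the core of compound 3 changes the number at all.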